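Cyano in Place of Hydrogen: Expecting Compound 4

The compounds below may be only part of what the source reports. "The series", "measured", "known", "first", "only" and "open" are said of these compounds alone.

Compound 1 `O=C(N/N=C/c1ccccc1)c1cnccn1` was tested in an ADME assay on J774 cells (Mus musculus) for cytotoxicity, read by MTT assay, with a stated time of 48 h, tested at 150 ug/mL (a higher number here means a weaker effect of the compound at the concentration tested, a lower number a stronger effect), where compound 1 gives 100%. Two measured compounds share its core and differ from it in one group. Compound 2 `O=C(N/N=C/c1ccccc1Br)c1cnccn1` carries bromo in place of hydrogen on an aromatic carbon; in this assay compound 2 gives 91%, which is a number 9 percentage points lower from compound 1 to compound 2 (within the scatter). Compound 3 `CCOc1ccc(/C=N/NC(=O)c2cnccn2)cc1` carries ethoxy in place of hydrogen on an aromatic carbon; in this assay compound 3 gives 100%, which is no change at the digits printed from compound 1 to compound 3 (within the scatter). Compound 1 therefore stands level with compound 3, and the two together hold the highest of the three numbers.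

Compound 4 `N#Cc1cccc(/C=N/NC(=O)c2cnccn2)c1` differs from compound 1 in one place: cyano in place of hydrogen on an aromatic carbon. The two measured steps that bear on this, both exchanges of hydrogen for a group on an aromatic carbon, stayed within the scatter, so no step beyond the scatter is expected in this assay. Compound 4 is expected to give 97%, between 85% and 100%, an expected step of a number 3 percentage points lower from compound 1 to compound 4 (within the scatter).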

Compound 4, a percentage reported as activity, at one concentration (the size of the read-out at that concentration, not a potency): 100%
For compound 4 the middle estimate is 3 percentage points below the measured one, and the stated range covers the measured number.
By their numbers in this assay, from the lowest: compounds 2, 1, 3 and 4 (each within the scatter of the next).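

The measurement in this assay adds a group of a new kind to the comparison: cyano, with its triple bond and hydrogen-bond acceptor, on an aromatic carbon meta to a large group, shows no change at the digits printed from compound 1 to compound 4 (within the scatter) and so joins bromo and ethoxy, whose steps from compound 1 also lie within the scatter. This read-out comes from a single concentration, so it gives the size of the effect at that concentration and not a potency. Nothing measured here offers an explanation for this result.

As far as these compounds go, whether an amine or a carboxylic acid at this same place would also stay within the scatter remains open. The same question holds for a longer chain, such as butoxy, in place of the ethoxy of compound 3.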